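Configuration steps in the series: an estimate for compound 4

The compounds below may be only part of what the source reports. "The series", "measured", "known", "first", "only" and "open" are said of these compounds alone.

Compound 3, `O=C(O)[C@H](CO)NC(=O)[C@@H]1C[C@H](O)CN1`, gives 0.39 h in an ADME assay on Jejunum (Mus musculus, strain C57BL/6) for metabolic stability, read by HPLC, with a stated time of 12 h; on this read-out higher numbers stand for a longer-lived compound and lower numbers for a shorter-lived compound. Of the two numbers measured, compound 3 stands highest, with compound 2, `O=C(O)[C@H](CO)NC(=O)[C@@H]1C[C@@H](O)CN1`, nearest at 0.35 h; the step of a 1.1-fold higher number from compound 2 to compound 3 (0.05 log units; within the scatter) sits within the scatter. Compound 1, `O=C(O)[C@H](CO)NC(=O)[C@H]1C[C@H](O)CN1`, is reported only as a limit of the assay, > 12 h. The steps down from compound 1 are large, an at least 30-fold lower number from compound 1 to compound 3 (1.48 log units; beyond the scatter) and an at least 34-fold lower number from compound 1 to compound 2 (1.53 log units; beyond the scatter), and in both pairs the compounds share every atom and bond (the fact that compounds 1 and 3 differ only in the configuration as drawn, (the fact that compounds 1 and 2 differ only in the configuration as drawn)).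

Compound 4, `O=C(O)[C@@H](CO)NC(=O)[C@H]1C[C@H](O)CN1`, is the next step: the two compounds have the same atoms and bonds and differ only in configuration as drawn: 2 of 3 stereo elements differ; a stereocentre at a saturated chain carbon is drawn S in compound 3 and R in compound 4; a stereocentre at a saturated ring carbon is drawn S in compound 3 and R in compound 4. The ring-carbon inversion gives compound 4 the ring configuration drawn for compound 1, so the step of an at least 30-fold lower number from compound 1 to compound 3 (1.48 log units; beyond the scatter) bears on it in reverse and points to a large rise. Going by the values given here, no measured step speaks to the chain-carbon inversion, and that part of the change has no support. Compound 4 is therefore expected to give 4 h in this assay, with a range from 0.5 h to 12 h. The expected step is a 10-fold higher number from compound 3 to compound 4 (1.01 log units; beyond the scatter), upward, with the chain-carbon part untested.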

Compound 4, half-life: > 12 h
Compound 4: a limit, no number (the forecaster's own chance of this, stated with the estimate: 35%); middle value at least 3.0-fold (0.47 log units) away from the limit.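

In this assay compound 4 gives > 12 h, which is a limit of the assay and not a number. With an at least 30-fold higher number from compound 3 to compound 4 (1.48 log units; beyond the scatter) and an at least 34-fold higher number from compound 2 to compound 4 (1.53 log units; beyond the scatter), the inverted ring carbon now accounts for the split in all four compounds shown: compounds 1 and 4, drawn alike there, sit at the limit, and compounds 2 and 3 do not. The chain carbon drawn R therefore does not pull the value down from that limit, though the step between compounds 1 and 4 cannot be read, since both values are limits: the limit of > 12 h in this assay, at which 2 of the 4 values shown sit.

As far as these compounds go, what the chain-carbon inversion alone does to a measurable value stays open, as does how far compounds 1 and 4 lie past the limit. Also open, from the compounds shown here alone, is whether the ring-carbon effect survives a methyl ether or a fluorine in place of the ring hydroxyl.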